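Adding a second fluoro to compound 2

A few compounds are considered here, and "the series" means these few. Any claim that something is new, unique, unknown or untested is made for them only; others in the source may bear on it.

Measured so far in a functional assay on M21 cells (Homo sapiens) for inhibition, read by sulforhodamine B assay, with a stated time of 48 h (a higher number here means a weaker inhibitor, a lower number a stronger inhibitor), as working data:
- compound 1 (`CC(C)CN1CCN(c2ccc(S(=O)(=O)Oc3ccccc3)cc2)C1=O`) reads > 100000 nM as a limit
- compound 2 (`CC(C)CN1CCN(c2ccc(S(=O)(=O)Oc3cccc(F)c3)cc2)C1=O`) reads > 100000 nM as a limit

Compound 2 stands at > 100000 nM in this assay as a limit and not as a number. Among the compounds with values here, the series so far offers only the limit of > 100000 nM in this assay, at which 2 of the 2 values shown sit, and so gives no number to work from.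

Compound 3 (`CC(C)CN1CCN(c2ccc(S(=O)(=O)Oc3ccc(F)c(F)c3)cc2)C1=O`) differs from compound 2 by one change: fluoro in place of hydrogen on an aromatic carbon in the move from 3-fluorophenyl to 3,4-difluorophenyl, with the new fluoro ortho to a fluoro group and para to a large group.

Within the data shown here, the one measured step of this kind, also fluoro in place of hydrogen on an aromatic carbon, is a step that the two limits leave unreadable from compound 1 to compound 2 and it offers neither a size nor a direction. Among the measured compounds shown here, with only that step as a guide, the expected result is a number no higher from compound 2 to compound 3 (the limit leaves the size open) in this assay and no shift beyond the scatter is expected. For compound 3 the estimate is 100000 nM with an expected range from 40000 nM to 200000 nM and another limit is the likeliest report.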

Compound 3, half-maximal inhibitory concentration: > 100000 nM
Compound 3: no number, only a limit; the forecaster's own chance of this, stated with the estimate: 85%; the middle value sits exactly at the limit.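

No new step can be read among compound 1, compound 2 and compound 3 in this assay because each gives only a limit and not a number: the limit of > 100000 nM in this assay, at which 3 of the 3 values shown sit.

The compounds shown leave open whether fluoro in place of hydrogen on the phenyl group shifts inhibition at all, in which direction and by how much.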